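The source may report more compounds than this note shows. Statements on the series, on what has been measured and on what is new or still open speak of the compounds shown alone.

In a functional assay on CHO cells for positive allosteric modulation of metabotropic glutamate receptor 2 (Homo sapiens), read by scintillation counting and GTPgammaS binding, with a stated time of 30 min (a higher number here means a larger maximal response, a lower number a smaller maximal response), three compounds have been measured so far. Compound 1, `COc1ccc(-c2ccn(CCC(C)C)c(=O)c2C#N)cc1`, gives 160%. Compound 2, `COc1ccc(-c2ccn(CCC(C)C)c(=O)c2C#N)cc1Cl`, gives 200%. The two differ in one place: chloro in place of hydrogen on an aromatic carbon, ortho to a methoxy group and meta to a large group. That change made a number 40 percentage points higher from compound 1 to compound 2 (beyond the scatter). Compound 3, `CCCCn1ccc(-c2ccc(Oc3ccnc(C)c3)cc2)c(C#N)c1=O`, is built on a different core, and how its core differs from that of compound 1 is not broken down here. In this assay compound 3 gives 243%, the highest of the three.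

Compound 4, `CCCCn1ccc(-c2ccc(Oc3ccnc(C)c3)cc2Cl)c(C#N)c1=O`, has not yet been measured. It arises from compound 3 by chloro in place of hydrogen on an aromatic carbon, here ortho to a large group and meta to a (2-methylpyridin-4-yl)oxy group, so the surroundings are not the same as between compound 1 and compound 2; it is the same kind of change, not the same change. Because the earlier change made a number 40 percentage points higher from compound 1 to compound 2 (beyond the scatter), a rise is expected for compound 4 as well, but a smaller one is estimated since compound 3 already reaches 243%. For compound 4 the expected step is a number 27 percentage points higher from compound 3 to compound 4 (beyond the scatter). Compound 4 is estimated to give 270%, most likely between 220% and 325%.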

Compound 4, largest response reached (Emax), in percent of the reference or control that the assay uses: 187%
Estimate against measurement, compound 4: 83 percentage points above; the whole stated range lies above it.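

On the newer core, chloro in place of hydrogen on an aromatic carbon gave a number 56 percentage points lower from compound 3 to compound 4 (beyond the scatter), so the change did not bring the rise seen on the core of compound 1. Set side by side, the two steps in this assay point in opposite directions: the same change on two cores in this assay, a number 40 percentage points higher (beyond the scatter) from compound 1 to compound 2 and a number 56 percentage points lower (beyond the scatter) from compound 3 to compound 4, 96 percentage points apart, beyond the scatter of two such steps. Among these compounds, this shows that a rise in maximal response from chloro on one core cannot simply be assumed on another core, but it does not show why the steps part, as there is only one pair for each core and the chloro sits in different surroundings in each pair.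

The compounds shown leave open which part of the two cores decides the direction of the step, and whether the drop belongs to chloro in particular. A fluoro group at the same place on the core of compound 3 would help separate these questions, as would chloro on a compound that differs from compound 3 in only one other place.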